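From Ethynyl to Phenyl: Expected Shift in Lipophilicity

A few compounds are considered here, and "the series" means these few. Any claim that something is new, unique, unknown or untested is made for them only; others in the source may bear on it.

Compound 1 `Cc1cc(Br)cc(C)c1Oc1ccnc(Nc2ccc(C#N)cc2)n1`: 1.72
Compound 2 `C#Cc1cnc(Nc2ccc(C#N)cc2)nc1Nc1c(C)cc(C)cc1C`: 1.63

In a physicochemical assay for lipophilicity (on this read-out lower numbers stand for lower lipophilicity and higher numbers for higher lipophilicity), compound 2 holds the lower of the two numbers, yet compound 1 sits only slightly higher, a gap within the usual scatter, so the two show no real difference. Compound 3 `Cc1cc(C)c(Nc2nc(Nc3ccc(C#N)cc3)ncc2-c2ccccc2)c(C)c1` differs from compound 2 by phenyl in place of ethynyl on an aromatic carbon. Within the data shown here, no measured pair shares this change, so its size cannot be read from the data. The change is nonetheless expected to raise this assay clearly beyond the scatter, and the estimated step is a number 0.97 log units higher from compound 2 to compound 3 (beyond the scatter). Compound 3 is therefore estimated at 2.6, expected between 2 and 3.3.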

Compound 3, partition coefficient: 3.14
For compound 3 the middle estimate is 0.54 log units below the measured one; measured number inside the range.
By their numbers in this assay, from the lowest: compounds 2 and 1 (each within the scatter of the next); then compound 3.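

Measured in this assay, phenyl in place of ethynyl on this aromatic carbon gives a number 1.51 log units higher from compound 2 to compound 3 (beyond the scatter) and so shows that this position can strongly shift the read-out. Among these compounds, this is the first single-place change available here, since compound 1 and compound 2 differ in more than one place. Nothing measured here explains the size of this step. From the compounds shown here alone, what an amine, a carboxylic acid or a longer carbon chain would do on this same carbon remains open. So does whether phenyl would give a similar step on the core of compound 1.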